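Propyl to 2-(dimethylamino)ethyl: notes on compound 4

The source may report more compounds than this note shows. Statements on the series, on what has been measured and on what is new or still open speak of the compounds shown alone.

In a functional assay on MKN-45 cells (Homo sapiens) for inhibition, with a stated time of 72 h (on this read-out higher numbers stand for weaker inhibition and lower numbers for stronger inhibition), compound 1 (`COc1cc(C(=O)c2ccc3cc[nH]c3c2)cc(OC)c1OC`) gives 480 nM and compound 2 (`COc1cc(C(=O)c2cccc3cc[nH]c23)cc(OC)c1OC`) gives 210 nM on the same read-out. Compound 3 (`CCCn1ccc2cc(C(=O)c3cc(OC)c(OC)c(OC)c3)ccc21`) gives 680 nM and so stands within the scatter of compound 1 and beyond the scatter above compound 2. Compound 4 (`COc1cc(C(=O)c2ccc3c(ccn3CCN(C)C)c2)cc(OC)c1OC`) differs from compound 3 by dimethylamino in place of methyl on a saturated chain carbon, two bonds along the chain from an aromatic nitrogen. For the measured compounds named here, no measured pair shows a change on this chain, so nothing measured gives its size directly. In this assay no step beyond the scatter is expected, and the expected step is a 1.2-fold higher number from compound 3 to compound 4 (0.07 log units; within the scatter) toward slightly weaker inhibition. Compound 4 is estimated at 800 nM with 280 nM to 2500 nM as its range.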

Compound 4, half-maximal inhibitory concentration: 2900 nM
The estimate for compound 4 lay 3.6-fold (0.56 log units) below the measured number; the whole stated range lies below it.
By their numbers in this assay, from the lowest: compound 2; then compounds 1 and 3 (each within the scatter of the next); then compound 4.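

In this assay, propyl to 2-(dimethylamino)ethyl gives a 4.3-fold higher number from compound 3 to compound 4 (0.63 log units; beyond the scatter), toward weaker inhibition. For the compounds shown here, this is the only measured change on this chain, and it shows that the position does not tolerate every group: dimethylamino in place of methyl lowers inhibition beyond the scatter. Nothing available explains the loss.

Going by these compounds, it remains open whether the loss follows the dimethylamino nitrogen or simply the added heavy atoms. The compounds shown offer no comparison with isobutyl, a hydroxyl, a carboxylic acid or a longer chain carrying the same amine.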